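A phenylethenyl group in place of a chlorophenyl ring

This account rests on a few compounds, and the source may have more. Where it says the series, first, only, none or still open, it means among the compounds named here.

Compound 1 `Cc1cc(O)c(C2=NN(c3ccc(S(N)(=O)=O)cc3)C(c3ccccc3O)C2)cc1Cl` and compound 2 `Cc1cc(O)c(C2=NN(c3ccc(S(N)(=O)=O)cc3)C(c3ccccc3Cl)C2)cc1Cl` share a core and differ in a single group. In a functional assay on CCRF-CEM cells (Homo sapiens) for antiproliferative activity, with a stated time of 48 h (a lower number here means that less compound is tolerated, a higher number that more compound is tolerated), compound 1 gives only a limit, > 100000 nM. In this assay compound 2 likewise gives only a limit, > 100000 nM. The step that the two limits leave unreadable from compound 1 to compound 2 cannot be read because both values sit at the limit (the limit of > 100000 nM in this assay, at which 2 of the 2 values shown sit). Compound 2 thus stands at the limit, with no number of its own. Compound 3 `Cc1cc(O)c(C2=NN(c3ccc(S(N)(=O)=O)cc3)C(/C=C/c3ccccc3)C2)cc1Cl` has not yet been measured. It differs from compound 2 by 2-phenylethenyl in place of 2-chlorophenyl on a saturated ring carbon. Among the measured compounds shown here, the only measured step, from compound 1 to compound 2, was unreadable, so no measured step gives a size or direction for this change. The expected step is a number no higher from compound 2 to compound 3 (the limit leaves the size open), no change beyond the scatter. For compound 3 in this assay the estimate is 100000 nM, spanning 30000 nM to 300000 nM.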

Compound 3, concentration lethal to 50% of the cells: > 100000 nM
Compound 3 ended at the assay's limit (the forecaster's own chance of this, stated with the estimate: 70%); the middle value sits exactly at the limit.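

Compound 3 gives only a limit in this assay, > 100000 nM. The steps among compound 1, compound 2 and compound 3 therefore cannot be read: the limit of > 100000 nM in this assay, at which 3 of the 3 values shown sit.

The compounds shown leave open whether changing the group on the saturated ring carbon alters the lethal concentration at all.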